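Removing the bromo from an inactive compound

The source may hold more compounds than are shown below. What is called first, only, known or untested is meant among the compounds shown, and "the series" means these compounds.

Compound 1 `Cc1nc2ccccc2n1-c1csc(Nc2cccc(Br)c2)n1`: 36000 nM
Compound 2 `Brc1ccc(Nc2nc(-n3cnc4ccccc43)cs2)cc1`: > 100000 nM (a limit, not a number)

In a functional assay on RKO cells (Homo sapiens) for cytotoxicity, read by resazurin assay, with a stated time of 72 h (a higher number here means a weaker inhibitor, a lower number a stronger inhibitor), compound 2 reads > 100000 nM, which is a limit of the assay and not a number.

Compound 3 `c1ccc(Nc2nc(-n3cnc4ccccc43)cs2)cc1` differs from it in one place: hydrogen in place of bromo on an aromatic carbon. This puts hydrogen in place of bromo on an aromatic carbon, turning 4-bromophenyl into phenyl.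

Within the data shown here, no measured pair shows this change, so only a small move towards a lower number is expected, and possibly none beyond the scatter. The expected change is an at least 1.1-fold lower number from compound 2 to compound 3 (0.04 log units; that floor lies within the scatter).

For compound 3 the estimate is 90000 nM, within an expected range of 30000 nM to 200000 nM.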

Compound 3, half-maximal inhibitory concentration: > 100000 nM
Compound 3: only a limit was reported (the forecaster's own chance of this, stated with the estimate: 60%); middle value at least 1.1-fold (0.04 log units) away from the limit.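

No step can be read from compound 2 to compound 3, as both give a limit rather than a number: the limit of > 100000 nM in this assay, at which 2 of the 3 values shown sit.

The compounds shown leave open whether hydrogen in place of bromo changes activity at all.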